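Trimming the Amine: Cyclopropyl to Methyl on a Shared Core

The source may report more compounds than this note shows. Statements on the series, on what has been measured and on what is new or still open speak of the compounds shown alone.

Of the compounds shown here, two sharing a core have been measured in a functional assay on EC9706 cells (Homo sapiens) for antiproliferative activity, read by MTT assay, with a stated time of 72 h; on this read-out lower numbers stand for stronger inhibition and higher numbers for weaker inhibition. Compound 1 `CN1CCN(C(=S)SCC2=CCOC2=O)CC1` gives 14300 nM. Compound 2 `O=C1OCC=C1CSC(=S)NC1CC1` gives 53600 nM, the higher of the two numbers, and the gap between compound 1 and compound 2 lies beyond the usual scatter. Compound 3 `CNC(=S)SCC1=CCOC1=O` has not yet been measured; it differs from compound 2 by methyl in place of cyclopropyl on an amide-type nitrogen, in words methyl in place of cyclopropyl on an amide-type nitrogen. Within the data shown here, no measured pair shows the effect of this exact change, so the size of the step is uncertain. The account expects compound 3 to land close to compound 2, with a step of a 1.3-fold lower number from compound 2 to compound 3 (0.13 log units; within the scatter) expected in this assay, which could fall either way and may not exceed the scatter. Compound 3 is therefore estimated at 40000 nM, within a range from 15000 nM to 110000 nM.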

Compound 3, half-maximal inhibitory concentration: 85400 nM
Compound 3: the middle estimate sits 2.1-fold (0.33 log units) below what was measured; the measured number falls inside the stated range.
By their numbers in this assay, from the lowest: compound 1; then compounds 2 and 3 (each within the scatter of the next).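

In this assay, among these compounds, methyl in place of cyclopropyl on the amide-type nitrogen gives a 1.6-fold higher number from compound 2 to compound 3 (0.20 log units; within the scatter) and so supplies the first measured step at this position. On this evidence, the cyclopropyl ring on this nitrogen can be exchanged for methyl without the number moving beyond the scatter, so the ring itself is not shown to matter for this read-out. Nothing measured here bears on why this step is as small as it is.

On these data alone, it remains open whether any other group on this nitrogen, such as a longer chain like n-butyl or a phenyl ring, would move the number beyond the scatter from compound 2. As far as these compounds go, it is equally open whether a chain ending in an amine or a carboxylic acid would do so.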